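The source may hold more compounds than are shown below. What is called first, only, known or untested is meant among the compounds shown, and "the series" means these compounds.

Measured in an assay on membranes from brain for binding affinity to Fatty-acid amide hydrolase 1 (Mus musculus), read by fluorescence, with stated times of 1 h and 30 min; a lower number here means a stronger inhibitor, a higher number a weaker inhibitor:
compound 1, `CN(CCN(C)C(=O)n1cccn1)Cc1ccc(OCc2ccccc2)cc1`, gives 510 nM.
compound 2, `CN(CCN(C)C(=O)n1cc(C#N)cn1)Cc1ccc(OCc2ccccc2)cc1`, gives 120 nM.
compound 3, `CN(CCN(C)C(=O)n1cccn1)Cc1cccc(OCc2ccccc2)c1`, gives 3000 nM.

Compound 3 gives the highest of the three numbers. Compound 1 and compound 3 are built from the same atoms joined differently; the difference between the two cores is not broken down here.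

One change recurs: cyano in place of hydrogen on an aromatic carbon, which gave a 4.3-fold lower number from compound 1 to compound 2 (0.63 log units; beyond the scatter). Compound 4, `CN(CCN(C)C(=O)n1cc(C#N)cn1)Cc1cccc(OCc2ccccc2)c1`, carries the same change on the core of compound 3: cyano in place of hydrogen on an aromatic carbon. The surroundings of the changed position read the same in both pairs, so this is the same change, seen only once so far.

Going by the values given here, for compound 4 the expected step in this assay is a 4.3-fold lower number from compound 3 to compound 4 (0.63 log units; beyond the scatter), resting on a 4.3-fold lower number from compound 1 to compound 2 (0.63 log units; beyond the scatter) as the single earlier instance. Compound 4 is therefore estimated at 700 nM, within 300 nM to 1800 nM.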

Compound 4, half-maximal inhibitory concentration: 190 nM
The estimate for compound 4 lay 3.7-fold (0.57 log units) above the measured number, outside the stated range (below it).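

Cyano in place of hydrogen on an aromatic carbon gives a 16-fold lower number from compound 3 to compound 4 (1.20 log units; beyond the scatter) in this assay, so the direction of the step seen on the core of compound 1 holds on the core of compound 3. The size of the step does not carry over between the two cores: the same change on two cores in this assay, a 4.3-fold lower number (0.63 log units; beyond the scatter) from compound 1 to compound 2 and a 16-fold lower number (1.20 log units; beyond the scatter) from compound 3 to compound 4, 3.7-fold (0.57 log units) apart, beyond the scatter of two such steps.
Two pairs show that a step measured on one core is a poor guide to its size on the other, but they do not show what in the cores sets the size, or how the change would read on a third core.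

Open, on these data alone, is how a chlorine or a carboxamide in place of cyano on that aromatic carbon would read on either core. Also open, as far as these compounds go, is whether the gap between the two steps would appear with those groups.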